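Shifting a chloro group: expected cytotoxicity of compound 4

The compounds below may be only part of what the source reports. "The series", "measured", "known", "first", "only" and "open" are said of these compounds alone.

Measured compounds:
compound 1 `O=C(COc1cccc2ccccc12)N/N=C/c1ccc(Cl)cc1`: 87.6 ug/mL
compound 2 `O=C(COc1cccc2ccccc12)N/N=C/c1ccc([N+](=O)[O-])cc1`: 87.9 ug/mL
compound 3 `C/C(=N\NC(=O)COc1cccc2ccccc12)c1ccc(Br)cc1`: 77.6 ug/mL

In an ADME assay on MT4 cells (Homo sapiens) for cytotoxicity, read by MTT assay, with a stated time of 4 days (on this read-out lower numbers stand for higher toxicity in this test and higher numbers for lower toxicity in this test), compound 1 gives 87.6 ug/mL and lies within the scatter of both compound 2 and compound 3, so no order among the three can be claimed. Among the measured compounds shown here, the only single-point step, a 1.0-fold higher number from compound 1 to compound 2 (0.00 log units; within the scatter), exchanges one substituent for another and leaves the number unchanged.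

Compound 4 `O=C(COc1cccc2ccccc12)N/N=C/c1cccc(Cl)c1` differs from compound 1 by 3-chlorophenyl in place of 4-chlorophenyl on a carbon with a double bond to nitrogen. For the measured compounds named here, no measured step moves a group from one ring position to another, so this change has no direct precedent here; the one step that is available changed nothing. Compound 4 is therefore expected to stay within the scatter, with an estimated step of a 1.0-fold lower number from compound 1 to compound 4 (0.01 log units; within the scatter). Compound 4 is estimated at 85 ug/mL, with a range from 55 ug/mL to 130 ug/mL.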

Compound 4, half-maximal cytotoxic concentration: 89.9 ug/mL
The estimate for compound 4 lay 1.1-fold (0.02 log units) below the measured number, within the range that was stated.
By their numbers in this assay, from the lowest: compounds 3, 1, 2 and 4 (each within the scatter of the next).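

In this assay, the change gives the first measured shift of a group between ring positions in this series, 3-chlorophenyl in place of 4-chlorophenyl, with a 1.0-fold higher number from compound 1 to compound 4 (0.01 log units; within the scatter). For this pair, the ring position of the chloro group therefore makes no readable difference to the number. No measurement on hand explains this result.

Going by these compounds, whether the same shift would leave the number within the scatter for the nitro group of compound 2 or the bromo group of compound 3 stays open. So does the outcome for an amine or a carboxylic acid in place of the chloro group.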